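Chromene ketones and a change on the carbonyl carbon

The source may report more compounds than this note shows. Statements on the series, on what has been measured and on what is new or still open speak of the compounds shown alone.

Compound 3 `CC1(C)C=C(n2ccccc2=O)c2cc(C(=O)c3ccc(O)cc3)ccc2O1` gives 6.65 in a functional assay (aorta) with Rattus norvegicus as the target (on this read-out lower numbers stand for lower potency and higher numbers for higher potency (the scale is a negative logarithm)), second highest of three numbers. Compound 1 `CC(=O)c1ccc2c(c1)C(n1ccccc1=O)=CC(C)(C)O2` gives 7.37, and compound 2 `COc1ccc(C(=O)c2ccc3c(c2)C(n2ccccc2=O)=CC(C)(C)O3)cc1` gives 6.15. Compound 4 `Cc1ccccc1C(=O)c1ccc2c(c1)C(n1ccccc1=O)=CC(C)(C)O2` differs from compound 3 only by 2-methylphenyl in place of 4-hydroxyphenyl on a carbonyl carbon. Among the compounds with values here, no measured step brings in 2-methylphenyl, so only aryl-for-methyl steps bear on it: a number 0.72 log units lower from compound 1 to compound 3 (beyond the scatter) and a number 1.22 log units lower from compound 1 to compound 2 (beyond the scatter), both lower. The step of a number 0.50 log units higher from compound 2 to compound 3 (beyond the scatter) shows the donor's loss costing potency. Compound 4 keeps an aryl ketone but gives up the hydrogen-bond donor, so a modest drop is expected, a number 0.45 log units lower from compound 3 to compound 4 (beyond the scatter). For compound 4 the estimate is 6.2 in this assay, ranging from 5.6 to 6.8.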

Compound 4, logarithm of the reciprocal of the active concentration, log(1/C): 6.83
Compound 4: the middle estimate sits 0.63 log units below what was measured, outside the stated range (above it).
By their numbers in this assay, from the lowest: compound 2; then compounds 3 and 4 (each within the scatter of the next); then compound 1.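

Giving up the hydrogen-bond donor of 4-hydroxyphenyl need not lower the number in this assay, since 2-methylphenyl on the carbonyl carbon leaves it level (a number 0.18 log units higher from compound 3 to compound 4 (within the scatter)). The same group stands clear of 4-methoxyphenyl (a number 0.68 log units higher from compound 2 to compound 4 (beyond the scatter)), so the aryl groups shown do not all behave alike, yet it remains short of methyl (a number 0.54 log units lower from compound 1 to compound 4 (beyond the scatter)), as do the other two aryl groups. No evidence shown accounts for these differences.

As far as these compounds go, whether 4-methylphenyl would match 2-methylphenyl stays open. So does whether a longer chain or an aminophenyl group on the carbonyl carbon would reach the number of compound 1.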